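Removing the N-methyl in a urate transporter inhibitor series

The source may hold more compounds than are shown below. What is called first, only, known or untested is meant among the compounds shown, and "the series" means these compounds.

Measured compounds and their numbers:
compound 1 `N#Cc1ccc(Nc2cnccc2SCCCC(=O)O)c2ccccc12`: 2780 nM
compound 2 `N#Cc1ccc(Nc2cnccc2SCCCCCCC(=O)O)c2ccccc12`: 5750 nM
compound 3 `CN(c1cnccc1SCCCCCC(=O)O)c1ccc(C#N)c2ccccc12`: 3760 nM

In an assay on HEK293 cells for inhibition of solute carrier family 22 member 12 (Homo sapiens), read by scintillation counting, with stated times of 30 min and 15 min (on this read-out higher numbers stand for weaker inhibition and lower numbers for stronger inhibition), compound 1 gives 2780 nM and compound 2 gives 5750 nM; the step of a 2.1-fold higher number from compound 1 to compound 2 (0.32 log units; beyond the scatter) lengthens the chain between the sulfur and the carboxylic acid. Compound 3 carries a methyl on the bridging nitrogen and gives 3760 nM in this assay; its number lies within the scatter of both compound 1 and compound 2, so no order among these three can be read from it.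

Compound 4 `N#Cc1ccc(Nc2cnccc2SCCCCCC(=O)O)c2ccccc12` has not yet been measured. It differs from compound 3 by hydrogen in place of methyl on a nitrogen on an aromatic ring. Among the compounds with values here, none of the measured steps touches this nitrogen; the only step known here, from compound 1 to compound 2, concerns the chain, so nothing measured bears directly on the change. With no guidance either way, compound 4 is expected to show a step of a 1.3-fold lower number from compound 3 to compound 4 (0.10 log units; within the scatter) in this assay, not beyond the scatter. Compound 4 is therefore estimated at 3000 nM, with a range from 1200 nM to 7500 nM.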

Compound 4, half-maximal inhibitory concentration: 4240 nM
The estimate for compound 4 lay 1.4-fold (0.15 log units) below the measured number; the measured number falls inside the stated range.
By their numbers in this assay, from the lowest: compounds 1, 3, 4 and 2 (each within the scatter of the next, the first and the last beyond it).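

In this assay, within the data shown here, the exchange of methyl for hydrogen on the nitrogen shows a 1.1-fold higher number from compound 3 to compound 4 (0.05 log units; within the scatter) and is the first direct reading at this position, where the two groups cannot be told apart. Compound 4 also adds a third chain length with hydrogen on the nitrogen: a 1.5-fold higher number from compound 1 to compound 4 (0.18 log units; within the scatter) and a 1.4-fold lower number from compound 2 to compound 4 (0.13 log units; within the scatter) each stay within the scatter, so the difference beyond the scatter between the shortest and longest chains cannot be assigned to either single step. No evidence accompanies these numbers to account for them.

The compounds shown leave open whether an ethyl or an acetyl group on this nitrogen would stay within the scatter of hydrogen and methyl, and whether methyl would behave the same way on the shortest and longest chains. They also leave open whether an amide or a tetrazole could stand in for the carboxylic acid.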